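Ester Variation at a Dihydropyridine Calcium Channel Antagonist Series

This account rests on a few compounds, and the source may have more. Where it says the series, first, only, none or still open, it means among the compounds named here.

Compound 1 `C=CCOC(=O)C1=C(C)NC(C)=C(C(=O)OC)C1c1cccc([N+](=O)[O-])c1`: 15 nM
Compound 2 `COC(=O)C1=C(C)NC(C)=C(C(=O)OCC(C)[N+](=O)[O-])C1c1cccc([N+](=O)[O-])c1`: 111 nM

In a functional assay on HEK293 cells for antagonist activity at Voltage-dependent L-type calcium channel subunit alpha-1D (Rattus norvegicus), read by FLIPR (on this read-out lower numbers stand for stronger inhibition and higher numbers for weaker inhibition), compound 1 gives 15 nM, and compound 2 gives 111 nM, the higher of the two numbers. Going by the values given here, the one measured step, a 7.4-fold higher number from compound 1 to compound 2 (0.87 log units; beyond the scatter), shows that changing the ester substituent at this position moves the read-out well beyond the scatter.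

Compound 3 `COC(=O)C1=C(C)NC(C)=C(C(=O)OCc2cc([N+](=O)[O-])cc([N+](=O)[O-])c2)C1c1cccc([N+](=O)[O-])c1` differs from compound 2 by 3,5-dinitrophenyl in place of 1-nitroethyl on a saturated chain carbon bound to an oxygen next to a carbonyl group. Among the compounds with values here, no measured step describes an aromatic ester here, so the outcome rests only on the fact that this position tolerates change of a modest size in this assay. Compound 3 is expected to land between the two measured values, with an expected step of a 1.9-fold lower number from compound 2 to compound 3 (0.27 log units; within the scatter). For compound 3 the estimate is 60 nM, with a range from 15 nM to 250 nM.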

Compound 3, half-maximal inhibitory concentration: 40 nM
Beside the measured number, compound 3's estimate is 1.5-fold (0.18 log units) above it; low and high end bracket the measured number.
By their numbers in this assay, from the lowest: compound 1; then compound 3; then compound 2.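

In this assay, this place on a saturated chain carbon bound to an oxygen next to a carbonyl group accepts an aromatic ring: 3,5-dinitrophenyl in place of 1-nitroethyl gives a 2.8-fold lower number from compound 2 to compound 3 (0.44 log units; beyond the scatter), so the larger group does not weaken inhibition relative to compound 2. Set against vinyl, the same group gives a 2.7-fold higher number from compound 1 to compound 3 (0.43 log units; beyond the scatter), which puts 3,5-dinitrophenyl in the middle of the three compounds rather than at either end, so the order does not simply follow the size of the group. Nothing available explains this order.

On these data alone, it remains open whether the ring itself or its two nitro groups account for the step, which an unsubstituted phenyl in the same place would help to separate. As far as these compounds go, how an amine or a longer chain there would compare also remains open.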